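This account rests on a few compounds, and the source may have more. Where it says the series, first, only, none or still open, it means among the compounds named here.

Values in a functional assay on SK-MEL-28 cells (Homo sapiens) for cytotoxicity, read by CCK-8 assay, with a stated time of 24 h; on this read-out higher numbers stand for weaker inhibition and lower numbers for stronger inhibition:
compound 1 `COc1ccccc1Oc1c(N)nc(-c2ccc(Cl)cc2)nc1Cl`: 120 nM
compound 2 `COc1ccccc1Oc1c(N)nc(Cc2ccccc2)nc1OCCO`: 14000 nM
compound 3 `COc1ccccc1Oc1c(N)nc(-c2ccc(C)cc2)nc1OCCO`: 6190 nM

Of these three, compound 3 stands in the middle at 6190 nM. Compound 2 gives a higher number, 14000 nM, and compound 1 a much lower one, 120 nM.

Compound 4 `COc1ccccc1Oc1c(N)nc(-c2ccc(Br)cc2)nc1OCCO` differs from compound 3 by a single change, bromo in place of methyl on an aromatic carbon. Among the compounds with values here, the only measured step is a 2.3-fold lower number from compound 2 to compound 3 (0.35 log units; beyond the scatter). It is modest and concerns 4-methylphenyl in place of benzyl, so it bears on the present change only indirectly. Compound 1 differs from compound 3 in more than one place, and its value gives no separate reading of this change. Within the data shown here, no measured step therefore points to a large shift or a firm direction. The expected step is a 1.4-fold lower number from compound 3 to compound 4 (0.14 log units; within the scatter), which would stay within the scatter. For compound 4 the estimated value in this assay is 4500 nM, with an expected range of 1500 nM to 11000 nM.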

Compound 4, half-maximal inhibitory concentration: 4400 nM
Estimate against measurement, compound 4: 1.0-fold (0.01 log units) above; the range from low to high includes it.
By their numbers in this assay, from the lowest: compound 1; then compounds 4 and 3 (each within the scatter of the next); then compound 2.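

In this assay, the change from 4-methylphenyl to 4-bromophenyl gives a 1.4-fold lower number from compound 3 to compound 4 (0.15 log units; within the scatter), so on this ring, para to a large group, methyl and bromo are not told apart. With benzyl replaced by 4-bromophenyl, there is a 3.2-fold lower number from compound 2 to compound 4 (0.50 log units; beyond the scatter), which gives a second modest step alongside a 2.3-fold lower number from compound 2 to compound 3 (0.35 log units; beyond the scatter); compounds 3 and 4 both carry a substituted phenyl and both give lower numbers than compound 2. Nothing at hand offers a reason for either step.

From the compounds shown here alone, whether an amine or a carboxylic acid in this same place would move the number beyond the scatter remains open. Compound 1, at 120 nM, differs from compound 4 in more than one place, so what separates the two cannot be assigned to any single change.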